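From Propylsulfanyl to Ethoxy at One Aromatic Carbon

This account rests on a few compounds, and the source may have more. Where it says the series, first, only, none or still open, it means among the compounds named here.

Compound 1 `Cc1cc(C2CCC2)c(S(C)(=O)=O)cc1C(=O)N=C(N)N`: 8.2 nM
Compound 2 `Cc1cc(-c2ccc(F)cc2)c(S(C)(=O)=O)cc1C(=O)N=C(N)N`: 36 nM
Compound 3 `CCCSc1cc(C)c(C(=O)N=C(N)N)cc1S(C)(=O)=O`: 6.8 nM

These three compounds share one core and differ only in the group on a single aromatic carbon. In a functional assay for inhibition of sodium/hydrogen exchanger (Oryctolagus cuniculus) (on this read-out higher numbers stand for weaker inhibition and lower numbers for stronger inhibition), compound 3 gives the lowest of the three numbers, yet the gap to compound 1 is small: a 1.2-fold lower number from compound 1 to compound 3 (0.08 log units; within the scatter), within the scatter. Compound 2 sits clearly apart, as a 5.3-fold lower number from compound 2 to compound 3 (0.72 log units; beyond the scatter) shows.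

Compound 4 `CCOc1cc(C)c(C(=O)N=C(N)N)cc1S(C)(=O)=O` is not yet measured. It differs from compound 3 in one place: ethoxy in place of propylsulfanyl on an aromatic carbon. For the measured compounds named here, no measured step involves ethoxy, so only the two steps that end at propylsulfanyl bear on it. One was within the scatter, the other modest, which suggests this position tolerates a chain-like group without a large change. For compound 4 a step of a 1.8-fold higher number from compound 3 to compound 4 (0.25 log units; within the scatter) in this assay is therefore expected, small and possibly within the scatter. The estimate for compound 4 is 12 nM, with a range from 4 nM to 40 nM.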

Compound 4, half-maximal inhibitory concentration: 19 nM
The estimate for compound 4 lay 1.6-fold (0.20 log units) below the measured number, within the range that was stated.
By their numbers in this assay, from the lowest: compounds 3 and 1 (each within the scatter of the next); then compounds 4 and 2 (each within the scatter of the next).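

In this assay the position separates two open-chain groups, ethoxy and propylsulfanyl, even though each has one hydrogen-bond acceptor and no ring (a 2.8-fold higher number from compound 3 to compound 4 (0.45 log units; beyond the scatter)). Ethoxy also stands apart from cyclobutyl (a 2.3-fold higher number from compound 1 to compound 4 (0.36 log units; beyond the scatter)), whereas its step from 4-fluorophenyl stays within the scatter (a 1.9-fold lower number from compound 2 to compound 4 (0.28 log units; within the scatter)). Having a ring or not therefore does not sort these four compounds: open-chain propylsulfanyl falls within the scatter of ring-bearing cyclobutyl, and open-chain ethoxy within that of ring-bearing 4-fluorophenyl.

This change swaps sulfur for oxygen and also shortens the chain, so the compounds shown cannot separate those two parts; propoxy or ethylsulfanyl at this carbon would do so. Nothing available explains why any of these steps has its size.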